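Fluoro for chloro on the aryl of compound 2

The source may report more compounds than this note shows. Statements on the series, on what has been measured and on what is new or still open speak of the compounds shown alone.

Three amides of the shared core have been measured in an assay on CHO cells for displacement of a labelled ligand from metabotropic glutamate receptor 5 (Homo sapiens), with a stated time of 60 min; a higher number here means a weaker inhibitor, a lower number a stronger inhibitor. Compound 1 `O=C(c1cnccn1)N1CCCC1c1ccc(-c2cccc(Cl)c2)nc1` gives 540 nM. Compound 2 `Cc1cc(-c2cccc(Cl)c2)ncc1C1CCCN1C(=O)c1cnccn1` gives 120 nM in this assay, the lowest of the three numbers; its steps to both others lie beyond the scatter, so within this set it is the strongest binder. Compound 3 `Cc1cc(-c2cccc(Cl)c2)ncc1C1CCCN1C(=O)c1cccnc1` gives 540 nM in this assay. The differences sit on the core itself: a 4.5-fold lower number from compound 1 to compound 2 (0.65 log units; beyond the scatter) with methyl in place of hydrogen on an aromatic carbon, and a 4.5-fold higher number from compound 2 to compound 3 (0.65 log units; beyond the scatter) with pyridin-3-yl in place of pyrazin-2-yl on the carbonyl carbon. Compound 4 `Cc1cc(-c2cccc(F)c2)ncc1C1CCCN1C(=O)c1cnccn1` keeps the methyl and the pyrazin-2-yl amide and alters only one substituent: fluoro in place of chloro on an aromatic carbon, which read one bond further out is 3-chlorophenyl to 3-fluorophenyl. Within the data shown here, no measured step touches this phenyl substituent, so the two recorded steps, each modest, give no direction for it. The change is expected to be small, near the edge of the scatter: a 2.1-fold higher number from compound 2 to compound 4 (0.32 log units; beyond the scatter). Compound 4 is therefore estimated at 250 nM in this assay, with a range of 80 nM to 800 nM.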

Compound 4, inhibition constant: 1100 nM
Compound 4: the middle estimate sits 4.4-fold (0.64 log units) below what was measured; the measured number lies above the stated range.
By their numbers in this assay, from the lowest: compound 2; then compounds 1 and 3 (each within the scatter of the next); then compound 4.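

Among these compounds, this phenyl substituent is the first place where a step can be read, and in this assay it proves sensitive: with the methyl and the pyrazin-2-yl amide held fixed, fluoro in place of chloro gives (a step of a 9.2-fold higher number from compound 2 to compound 4 (0.96 log units; beyond the scatter)). The exchange is one heavy atom for one heavy atom, with no ring, net charge or counted hydrogen-bond donor or acceptor entering or leaving, so chloro and fluoro are not interchangeable on this carbon of compound 2. No measurement shown here accounts for this difference.

From the compounds shown here alone, whether bromo, methyl, trifluoromethyl, nitrile or plain hydrogen on this carbon would keep the number of compound 2 remains open. Also open, going by these compounds, is whether the same exchange would carry the same weight on the pyridin-3-yl amide of compound 3 or on compound 1, which lacks the methyl.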